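A few compounds are considered here, and "the series" means these few. Any claim that something is new, unique, unknown or untested is made for them only; others in the source may bear on it.

Working notes on the series. In a functional assay on HCT-116 cells (Homo sapiens) for cytotoxicity, read by MTT assay, with a stated time of 24 h (on this read-out lower numbers stand for stronger inhibition and higher numbers for weaker inhibition), compound 1 (`COc1cccc(-n2cc(COc3c(/C=C\C(=O)O)ccc(OC)c3CC=C(C)C)nn2)c1`) gives 21600 nM and lies within the scatter of both other measured compounds: compound 2 (`COc1ccc(/C=C\C(=O)O)c(OCc2cn(-c3cccc(C#N)c3)nn2)c1CC=C(C)C`) gives 35300 nM and compound 3 (`COc1ccc(/C=C\C(=O)O)c(OCc2cn(-c3ccccc3C(=O)N3CCC(O)C3)nn2)c1CC=C(C)C`) gives 32000 nM in the same read-out. Going by the values given here, no member of this small set stands apart.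

Compound 4 (`COc1ccc(/C=C\C(=O)O)c(OCc2cn(-c3cccnc3Cl)nn2)c1CC=C(C)C`) has not yet been measured. It differs from compound 1 on an aromatic nitrogen of a five-membered aromatic ring with 3 nitrogen, where 2-chloropyridin-3-yl stands in place of 3-methoxyphenyl (2-chloropyridin-3-yl in place of 3-methoxyphenyl on an aromatic nitrogen) and the rest of the core of compound 1 is kept.

Among the compounds with values here, one measured step bears directly on this change. Cyano in place of methoxy on an aromatic carbon of the same group gives a 1.6-fold higher number from compound 1 to compound 2 (0.21 log units; within the scatter) and stays within the scatter. Compound 3 carries a different aromatic group on the same nitrogen. Compared with compound 1, compound 3 at 32000 nM also lies within the scatter in this series. Within the data shown here, no measured compound has a chlorine or a ring nitrogen in this group, so the evidence is indirect.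

No step beyond the scatter is therefore expected in this assay in either direction. The estimated change is a 1.3-fold higher number from compound 1 to compound 4 (0.11 log units; within the scatter) and it would not count as a real shift. For compound 4 the expected value is 28000 nM with an estimated range from 14000 nM to 55000 nM in this read-out.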

Compound 4, half-maximal inhibitory concentration: 23000 nM
For compound 4 the middle estimate is 1.2-fold (0.09 log units) above the measured one; measured number inside the range.
By their numbers in this assay, from the lowest: compounds 1, 4, 3 and 2 (each within the scatter of the next).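

Replacing 3-methoxyphenyl with 2-chloropyridin-3-yl on the aromatic nitrogen gives, in this assay, a 1.1-fold higher number from compound 1 to compound 4 (0.03 log units; within the scatter) and, against the nitrile-bearing group, a 1.5-fold lower number from compound 2 to compound 4 (0.19 log units; within the scatter) in this read-out. The earlier compounds shown here carried only carbon aromatic rings at this position, whereas compound 4 shows that a ring with a hetero atom, together with a chlorine, can stand here without a step beyond the scatter. No independent measurement accompanies this result, so the data offer no explanation for the absence of a real shift.

The ring nitrogen and the chlorine enter together in compound 4, so their separate contributions cannot be told apart, and a plain phenyl or a 2-chlorophenyl group at this position would be needed to separate them. The compounds shown also leave open whether any group on this nitrogen moves the number beyond the scatter, for instance a saturated piperidine ring, a longer alkyl chain or an aromatic ring bearing a primary amine.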